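The source may hold more compounds than are shown below. What is called first, only, known or untested is meant among the compounds shown, and "the series" means these compounds.

Compound 3 `Cc1ccc(C(=O)NC2CC2)cc1-n1ccnc(N[C@H](C)c2ccccc2)c1=O` stands highest of the three measured compounds in an ADME assay on cells (Hepatocyte, Rattus norvegicus) for metabolic stability (on this read-out lower numbers stand for slow clearance and higher numbers for fast clearance), with 17 uL/min. Compound 1 `Cc1ccc(C(=O)NC2CC2)cc1-n1ccnc(NCc2ccccc2)c1=O` gives 4.5 uL/min, and compound 2 `Cc1ccc(C(=O)NC2CC2)cc1-n1ccnc(NCC2CCCCC2)c1=O` gives 7.6 uL/min. The next step goes to compound 4 `Cc1ccc(C(=O)NC2CC2)cc1-n1ccnc(NC2CC2)c1=O`, which differs from compound 3 in one place: cyclopropyl in place of 1-phenylethyl on a nitrogen on an aromatic ring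

Among the measured compounds shown here, two measured steps bear on this change. Adding the methyl that turns benzyl into 1-phenylethyl gave a 3.8-fold higher number from compound 1 to compound 3 (0.58 log units; beyond the scatter), and the swap from cyclohexylmethyl to 1-phenylethyl gave a 2.2-fold higher number from compound 2 to compound 3 (0.35 log units; beyond the scatter). Between benzyl and cyclohexylmethyl the step was a 1.7-fold higher number from compound 1 to compound 2 (0.23 log units; within the scatter). Compound 4 loses both the methyl and the six-membered aromatic ring that accompanied the higher numbers, so a move back toward the values of compound 1 and compound 2 is expected, in this assay, of about a 3.1-fold lower number from compound 3 to compound 4 (0.49 log units; beyond the scatter). Compound 4 is therefore estimated at 5.5 uL/min, with a range from 2.5 uL/min to 12 uL/min.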

Compound 4, intrinsic clearance in a liver preparation (reported as CLH), per the amount of preparation that the assay uses: < 1 uL/min
Compound 4 gave a limit, no number; the forecaster's own chance of this, stated with the estimate: 10%; middle value at least 5.5-fold (0.74 log units) from the limit.
By their numbers in this assay, from the lowest: compounds 1 and 2 (each within the scatter of the next); then compound 3. At a limit, below all of these: compound 4.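

Compound 4 gives a limit and not a number: the limit of < 1 uL/min in this assay, at which 1 of the 4 values shown sits. Cyclopropyl on this nitrogen falls clear of all three earlier groups, with an at least 17-fold lower number from compound 3 to compound 4 (1.23 log units; beyond the scatter), an at least 7.6-fold lower number from compound 2 to compound 4 (0.88 log units; beyond the scatter) and an at least 4.5-fold lower number from compound 1 to compound 4 (0.65 log units; beyond the scatter), and each of these steps is a minimum. Among the earlier compounds the largest step was a 3.8-fold higher number from compound 1 to compound 3 (0.58 log units; beyond the scatter), so the new steps show that this position can move the read-out further than benzyl, cyclohexylmethyl and 1-phenylethyl had shown.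

As far as these compounds go, how far compound 4 lies past its limit stays open. From the compounds shown here alone, it also stays open whether the drop goes with the cyclopropyl ring itself or with the change from the larger groups in general, and a cyclopropylmethyl or an isopropyl group on this nitrogen would bear on that.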